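Methyl for Chloro on the Aryl Ring of Compound 3

The source may report more compounds than this note shows. Statements on the series, on what has been measured and on what is new or still open speak of the compounds shown alone.

Of the compounds shown here, three built on a shared core have been tested in an assay on HEK-293T cells for displacement of a labelled ligand from corticotropin-releasing factor receptor 1 (Homo sapiens), read by scintillation counting, with a stated time of 2 h; on this read-out lower numbers stand for stronger inhibition and higher numbers for weaker inhibition. Compound 1 `CCCCN(CC)c1cc(C)nc2c1NC(=O)CN2c1ccc(C(C)(C)C)cc1Br` gives 4.2 nM, compound 2 `CCN(C)c1cc(C)nc2c1NC(=O)CN2c1ccc(C(C)C)cc1Br` gives 16.4 nM, and compound 3 `CCCCN(CC)c1cc(C)nc2c1NC(=O)CN2c1ccc(Br)cc1Cl` gives 2.7 nM. Compound 3 has the lowest number of the three. Its nearest neighbour is compound 1, whose number sits higher by a gap that lies within the usual scatter, so the two cannot be ordered against each other. Compound 2 sits beyond the scatter, so compound 3 inhibits more strongly than compound 2.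

Compound 4 `CCCCN(CC)c1cc(C)nc2c1NC(=O)CN2c1ccc(Br)cc1C` has not yet been measured. It differs from compound 3 by methyl in place of chloro on an aromatic carbon. Among the measured compounds shown here, no measured pair in this set shows this exchange, so no step can be read from the data. One heavy atom is swapped for another of the same count, with no change in donors, acceptors or charge; the step of a 1.3-fold higher number from compound 3 to compound 4 (0.11 log units; within the scatter) is therefore expected to stay within the scatter, with no clear direction. The expected value for compound 4 in this assay is 3.5 nM, with a range from 1.5 nM to 9 nM.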

Compound 4, inhibition constant: 4.4 nM
Estimate against measurement, compound 4: 1.3-fold (0.10 log units) below; low and high end bracket the measured number.
By their numbers in this assay, from the lowest: compounds 3, 1 and 4 (each within the scatter of the next); then compound 2.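

The exchange of 4-bromo-2-chlorophenyl for 4-bromo-2-methylphenyl gives, in this assay, a 1.6-fold higher number from compound 3 to compound 4 (0.21 log units; within the scatter), so at this place, ortho to a large group and meta to a bromo group, chloro and methyl cannot be told apart. Among the compounds shown here, this is the only pair in the set that differs in one place, so it gives the first direct reading of any single exchange, though on the background of compound 3 alone. Nothing measured here bears on why the two groups read alike.

From the compounds shown here alone, it remains open whether a methoxy group, a trifluoromethyl group or a plain hydrogen at this place would also stay within the scatter. Going by these compounds, it is also open whether methyl would read the same way with the tert-butyl or isopropyl groups of compound 1 and compound 2.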